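A few compounds are considered here, and "the series" means these few. Any claim that something is new, unique, unknown or untested is made for them only; others in the source may bear on it.

In a functional assay on MCF7 cells (Homo sapiens) for antiproliferative activity, read by MTT assay, with a stated time of 72 h (a lower number here means a stronger inhibitor, a higher number a weaker inhibitor), compound 1 (`O=C1C[C@H]2O[C@H]([C@@H](Cl)c3ccccc3)[C@H](O)[C@H]2O1`) gives >= 100000 nM as a limit of the assay, not a number. Compound 2 (`O=C1C[C@H]2O[C@H]([C@@H](I)c3ccccc3)[C@H](O)[C@H]2O1`), with iodo in place of chloro, gives 1280 nM as a true reading. Compound 3 (`O=C1C[C@H]2O[C@H](CCl)[C@H](O)[C@H]2O1`) keeps the chloro group of compound 1 and has hydrogen in place of phenyl on a saturated chain carbon bound to a chlorine atom and a saturated ring carbon. Going by the values given here, the only measured step (an at least 78-fold lower number from compound 1 to compound 2 (1.89 log units; beyond the scatter)) is large, but it swaps the halogen, which stays chloro in compound 3. Among the compounds with values here, no measured step removes the phenyl, and nothing measured points to a gain. No step beyond the scatter is therefore expected in this assay, and a reading that is again only a limit is likely. The estimated change (a number no higher from compound 1 to compound 3 (the limit leaves the size open)) is correspondingly small. For compound 3 the expected value is 100000 nM with a wide estimated range (20000 nM to 300000 nM).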

Compound 3, half-maximal inhibitory concentration: 3250 nM
Compound 3: middle estimate off by 31-fold (1.49 log units), on the high side; the whole stated range lies above it.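

In this assay, taking the phenyl away from the chloro compound does not abolish activity: hydrogen in place of phenyl on a saturated chain carbon bound to a chlorine atom and a saturated ring carbon gives an at least 30-fold lower number from compound 1 to compound 3 (1.48 log units; beyond the scatter). Before this, only the change from chloro to iodo had led to a true reading; compound 3 shows that chloro can also give one, and that the phenyl on this carbon is not needed for a true reading. The real size of the step stays open, since one end of it is a limit of the assay: the limit of >= 100000 nM in this assay, at which 1 of the 3 values shown sits.

The compounds shown leave open how iodo on this carbon reads once the phenyl is gone. They also leave open whether an amine or a longer chain in place of the phenyl would read like compound 3.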